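The compounds below may be only part of what the source reports. "The series", "measured", "known", "first", "only" and "open" are said of these compounds alone.

Working notes on the cyclic peroxide series.

Compound 1 `C=C(c1ccc(F)c(F)c1)C1COC(C)(C)OO1` carries two fluoro groups on the aromatic ring and the dimethyl-substituted peroxide core. In a functional assay on L02 cells (Homo sapiens) for inhibition, read by MTT assay, with a stated time of 72 h (a lower number here means a stronger inhibitor, a higher number a weaker inhibitor), compound 1 gives only a limit of the assay, > 100000 nM. Compound 2 `C=C(c1ccc(OC)c(F)c1)C1COC(C)(C)OO1` differs from compound 1 by methoxy in place of fluoro on an aromatic carbon. In this assay compound 2 likewise reaches only a limit, > 100000 nM. Consequently the step from compound 1 to compound 2, a step that the two limits leave unreadable from compound 1 to compound 2, cannot be sized, because of the limit of > 100000 nM in this assay, at which 2 of the 3 values shown sit.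

Compound 3 `C=C(c1ccc(F)c(F)c1)C1COC2(CCCCC2)OO1` keeps the difluoro aromatic ring of compound 1 on a spiro-cyclohexyl peroxide core; the difference between the two cores is not broken down here. In this assay, for the measured compounds named here, compound 3 gives 16500 nM, the only actual number in the set so far.

Compound 4 `C=C(c1ccc(OC)c(F)c1)C1COC2(CCCCC2)OO1` is not yet measured. It differs from compound 3 by methoxy in place of fluoro on an aromatic carbon, the same change as from compound 1 to compound 2, at a place described in identical words. Since the step from compound 1 to compound 2 is unreadable, the expectation for compound 4 rests on compound 3 alone, whose value of 16500 nM is taken as the anchor. The step from compound 3 to compound 4 is expected to be small, a 1.2-fold higher number from compound 3 to compound 4 (0.08 log units; within the scatter), with a wide range allowed. The estimate for compound 4 in this assay is 20000 nM, between 7000 nM and 60000 nM.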

Compound 4, half-maximal inhibitory concentration: 15400 nM
Beside the measured number, compound 4's estimate is 1.3-fold (0.11 log units) above it; the measured number falls inside the stated range.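

On the core of compound 3, methoxy in place of fluoro on an aromatic carbon gives a 1.1-fold lower number from compound 3 to compound 4 (0.03 log units; within the scatter), so the two compounds cannot be told apart in this assay. The same change on the core of compound 1 cannot be read, because compound 1 and compound 2 each give only a limit of the assay and no number: the limit of > 100000 nM in this assay, at which 2 of the 4 values shown sit. This leaves a single readable step on a single core, which shows that the change is tolerated on the core of compound 3 but does not show that its outcome carries over from one core to the other.

On these data alone, what an amine or a carboxylic acid on the same aromatic carbon would give in this assay remains open, as does the result of a longer chain ending in an ether oxygen there. Also open, as far as these compounds go, is how methoxy in place of fluoro behaves on any further core that gives a number rather than a limit.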